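Smaller aromatic substituent on a nucleoside core: expectation

The source may report more compounds than this note shows. Statements on the series, on what has been measured and on what is new or still open speak of the compounds shown alone.

Measured compounds in a functional assay on HeLa S3 cells (Homo sapiens) for antiproliferative activity, read by XTT assay, with a stated time of 72 h; a higher number here means a weaker inhibitor, a lower number a stronger inhibitor:
Compound 1, `Nc1nc(N)c2c(-c3cc4ccccc4o3)cn([C@@H]3O[C@H](CO)[C@@H](O)[C@H]3O)c2n1`: > 20000 nM
Compound 2, `Cc1nc(N)c2c(-c3cc4ccccc4o3)cn([C@@H]3O[C@H](CO)[C@@H](O)[C@H]3O)c2n1`: > 20000 nM

Compound 2 gives only a limit of the assay in this assay, not a number. Compound 1 likewise gives only a limit there. The step that the two limits leave unreadable from compound 1 to compound 2 is therefore unreadable, as the limit of > 20000 nM in this assay, at which 2 of the 2 values shown sit, records. Compound 3, `Cc1nc(N)c2c(-c3cccs3)cn([C@@H]3O[C@H](CO)[C@@H](O)[C@H]3O)c2n1`, differs from compound 2 by thiophen-2-yl in place of 1-benzofuran-2-yl on an aromatic carbon. Within the data shown here, no measured step touches this change, so the expectation for compound 3 rests on the standing of compound 2 alone. Compound 3 is expected to stay at about the same level, a number no higher from compound 2 to compound 3 (the limit leaves the size open), most likely again as a limit. The estimate for compound 3 is 20000 nM, within 5000 nM to 60000 nM.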

Compound 3, half-maximal inhibitory concentration: > 20000 nM
Compound 3: no number, only a limit; the forecaster's own chance of this, stated with the estimate: 80%; the middle value lies on the limit itself.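

No step can be read between compound 2 and compound 3, as both give only a limit of the assay: the limit of > 20000 nM in this assay, at which 3 of the 3 values shown sit.

The compounds shown leave open whether thiophen-2-yl and 1-benzofuran-2-yl differ at all in this assay.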